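Hydroxyphenyl for chlorobenzyl on the purine amine

A few compounds are considered here, and "the series" means these few. Any claim that something is new, unique, unknown or untested is made for them only; others in the source may bear on it.

The compounds share a common core and differ at the group on the ring nitrogen and at the chain on the other nitrogen. Among the measured compounds shown here, compound 1 `CC(C)CCn1cnc2c(NCc3cccc(Cl)c3)nc(N[C@H]3CC[C@H](N)CC3)nc21` has the highest of the two numbers so far: in a functional assay on HCC827 cells (Homo sapiens) for inhibition, read by fluorescence, with a stated time of 72 h (on this read-out higher numbers stand for weaker inhibition of growth and lower numbers for stronger inhibition of growth), compound 1 gives 16700 nM. Compound 2 `CCCCn1cnc2c(Nc3cccc(Cl)c3)nc(N[C@H]3CC[C@H](N)CC3)nc21` gives 7200 nM in this assay, a lower number than compound 1 by a margin beyond the usual scatter. For the measured compounds named here, no single-point step between the two measured compounds is available, so what separates them is read only from the two values.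

Compound 3 `CC(C)CCn1cnc2c(Nc3ccc(O)cc3)nc(N[C@H]3CC[C@H](N)CC3)nc21` is not yet measured. It differs from compound 1 by 4-hydroxyphenyl in place of 3-chlorobenzyl on a nitrogen on an aromatic ring. Going by the values given here, with no measured pair showing exactly this change, the direction of the step rests on the two values alone, and compound 3 is expected to land at a somewhat lower number than compound 1, a step from a 2.4-fold lower number from compound 1 to compound 3 (0.38 log units; beyond the scatter) that is expected to be modest but beyond the scatter. In this assay compound 3 is therefore estimated at 7000 nM, within a range from 2500 nM to 20000 nM.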

Compound 3, concentration for 50% growth inhibition: 14400 nM
The estimate for compound 3 lay 2.1-fold (0.31 log units) below the measured number; the measured number falls inside the stated range.
By their numbers in this assay, from the lowest: compounds 2, 3 and 1 (each within the scatter of the next, the first and the last beyond it).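

Read in this assay, the exchange of 3-chlorobenzyl for 4-hydroxyphenyl on a nitrogen on an aromatic ring gives a 1.2-fold lower number from compound 1 to compound 3 (0.06 log units; within the scatter), the first single-place comparison among these compounds. This place therefore accepts a substantial change of group with no difference beyond the scatter: the chlorine and one carbon leave, while an oxygen enters, and with it the hydrogen-bond donor and hydrogen-bond acceptor counted for 4-hydroxyphenyl. Growth inhibition stays in the same weak range across this pair, and nothing given here explains why the exchange leaves the two readings level.

Because the exchange alters the aromatic group's substituent and its attachment to the nitrogen together, this single step cannot show whether either alteration alone would have an effect, or whether the two offset each other; 4-hydroxybenzyl or 3-chlorophenyl carrying the same chain on the ring nitrogen would separate them. As far as these compounds go, it also remains open whether a methoxy group, an amine or a carboxylic acid in place of the hydroxyl would read level with compound 3, and whether a longer chain on the ring nitrogen would shift the reading.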